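This account rests on a few compounds, and the source may have more. Where it says the series, first, only, none or still open, it means among the compounds named here.

Two members of the series carry a value in a functional assay on A549 cells (Homo sapiens) for inhibition, read by MTT assay, with a stated time of 72 h; a lower number here means a stronger inhibitor, a higher number a weaker inhibitor. Compound 1 `CN(C(=O)NC(=O)c1ccc(C(F)(F)F)cc1)c1nc(C(F)(F)F)c(C(=O)N/N=C/c2ccc(C(F)(F)F)cc2)s1` does not give a number there: in this assay compound 1 gives > 100 ug/mL, which is a limit of the assay and not a measurement, as noted in the limit of > 100 ug/mL in this assay, at which 1 of the 2 values shown sits. Among the compounds with values here, compound 2 `CN(C(=O)NC(=O)c1cccc([N+](=O)[O-])c1)c1nc(C(F)(F)F)c(C(=O)N/N=C/c2ccccc2C(F)(F)F)s1` holds the only real number on this axis, and in this assay compound 2 gives 5.45 ug/mL. Compound 2 thus stands alone as the fixed point of the series. Compound 3 `CN(C(=O)NC(=O)c1ccc(C(F)(F)F)cc1)c1nc(C(F)(F)F)c(C(=O)N/N=C/c2ccccc2C(F)(F)F)s1` is not yet measured. It differs from compound 2 in one place: 4-(trifluoromethyl)phenyl in place of 3-nitrophenyl on a carbonyl carbon. Within the data shown here, no measured pair isolates this change, so its size cannot be read from the data. The step of a 4.6-fold higher number from compound 2 to compound 3 (0.66 log units; beyond the scatter) is expected to run toward weaker inhibition, beyond the usual scatter, with a fair chance that only a limit is returned. The estimate for compound 3 in this assay is 25 ug/mL, within 6 ug/mL to 100 ug/mL.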

Compound 3, half-maximal inhibitory concentration: 6.68 ug/mL
Compound 3: the middle estimate sits 3.7-fold (0.57 log units) above what was measured, within the range that was stated.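

In this assay, 4-(trifluoromethyl)phenyl in place of 3-nitrophenyl on a carbonyl carbon gives a 1.2-fold higher number from compound 2 to compound 3 (0.09 log units; within the scatter), so with 2-(trifluoromethyl)phenyl held constant on the carbon with a double bond to nitrogen, these two groups are not told apart at this position. The second place now shows a step beyond the scatter: 2-(trifluoromethyl)phenyl in place of 4-(trifluoromethyl)phenyl on that carbon gives an at least 14-fold lower number from compound 1 to compound 3 (1.17 log units; beyond the scatter). Compound 1 carries a limit and not a number: the limit of > 100 ug/mL in this assay, at which 1 of the 3 values shown sits.

Still open, from the compounds shown here alone, is whether the carbonyl position accepts groups of another kind, such as a 4-aminophenyl, a 4-carboxyphenyl or an unsubstituted phenyl. Also open, going by these compounds, is whether the step at the carbon with a double bond to nitrogen holds when 3-nitrophenyl stands on the carbonyl carbon.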